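The source may hold more compounds than are shown below. What is called first, only, known or untested is meant among the compounds shown, and "the series" means these compounds.

In a functional assay on CFPAC-1 cells (Homo sapiens) for antiproliferative activity, read by MTT assay, with a stated time of 72 h (on this read-out lower numbers stand for stronger inhibition and higher numbers for weaker inhibition), compound 1 `CCCCc1cn(C[C@H](O)[C@H]2OC(=O)C(OCc3ccccc3)=C2OCc2ccccc2)nn1` gives 73200 nM and compound 2 `C[Si](C)(C)c1cn(C[C@H](O)[C@H]2OC(=O)C(OCc3ccccc3)=C2OCc2ccccc2)nn1` gives 52600 nM while compound 3 `Cc1ccc(S(=O)(=O)NCc2cn(C[C@H](O)[C@H]3OC(=O)C(OCc4ccccc4)=C3OCc3ccccc3)nn2)cc1` gives 68000 nM in the same range. Compound 3 cannot be told apart from either of the others, since a 1.3-fold higher number from compound 2 to compound 3 (0.11 log units; within the scatter) also lies within the scatter. The change to compound 4 `O=C1O[C@H]([C@@H](O)Cn2cc(CCO)nn2)C(OCc2ccccc2)=C1OCc1ccccc1` is hydroxymethyl in place of ((4-methylphenyl)sulfonyl)amino on a saturated chain carbon bound to an aromatic carbon. Among the measured compounds shown here, the only measured exchange at that place is a 1.1-fold lower number from compound 1 to compound 3 (0.03 log units; within the scatter) and it stays within the scatter. For the measured compounds named here, no measured compound carries hydroxymethyl there. No step beyond the scatter is therefore expected in this assay and the estimate is a 1.0-fold higher number from compound 3 to compound 4 (0.01 log units; within the scatter) in expectation. Compound 4 is estimated at 70000 nM with an expected range from 33000 nM to 150000 nM as its upper end.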

Compound 4, half-maximal inhibitory concentration: > 100000 nM
Compound 4 was reported as a limit (the forecaster's own chance of this, stated with the estimate: 20%); middle value at least 1.4-fold (0.15 log units) away from the limit.
By their numbers in this assay, from the lowest: compounds 2, 3 and 1 (each within the scatter of the next). At a limit, above all of these: compound 4.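

In this assay compound 4 is reported only as a limit: the limit of > 100000 nM in this assay, at which 1 of the 4 values shown sits. Among the compounds shown here, the change from (((4-methylphenyl)sulfonyl)amino)methyl to 2-hydroxyethyl is thus the only exchange at this place whose size has no upper bound, as the steps show: an at least 1.4-fold higher number from compound 3 to compound 4 (0.16 log units; that floor lies within the scatter), an at least 1.9-fold higher number from compound 2 to compound 4 (0.27 log units; that floor lies within the scatter) and an at least 1.3-fold higher number from compound 1 to compound 4 (0.13 log units; that floor lies within the scatter). Each floor stays within the scatter, so the small hydroxyl-bearing chain is not shown to differ from the other groups, though nothing in it brings a gain.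

From the compounds shown here alone, how far compound 4 truly lies from the others stays open. So does whether an amine or a carboxylic acid on this chain would give a measurable number in this assay.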